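A Methyl Added Where Three Compounds Show No Toxicity

The compounds below may be only part of what the source reports. "The series", "measured", "known", "first", "only" and "open" are said of these compounds alone.

Compound 1 `CC1CCCCN1c1nc(Cc2c(F)cccc2F)cc(=O)[nH]1` gives > 78000 nM in an ADME assay on MT4 cells (Homo sapiens) for cytotoxicity, read by MTT assay, with a stated time of 4 days (on this read-out higher numbers stand for lower toxicity in this test and lower numbers for higher toxicity in this test), which is a limit of the assay rather than a number.
Compound 2 `CC1CCN(c2nc(Cc3c(F)cccc3F)cc(=O)[nH]2)CC1` gives > 78000 nM, again a limit.
Compound 3 `O=c1cc(Cc2c(F)cccc2F)nc(N2CCCCCC2)[nH]1` gives > 78000 nM, again a limit.

In this assay compound 1 therefore stands only at a limit, and the two further values shown are the same limit, as the limit of > 78000 nM in this assay, at which 3 of the 3 values shown sit, records. Going by the values given here, the steps a step that the two limits leave unreadable from compound 1 to compound 2, a step that the two limits leave unreadable from compound 1 to compound 3 and a step that the two limits leave unreadable from compound 2 to compound 3 cannot be read for size or direction, since no compound leaves the limit. Among the compounds with values here, compound 4 `Cc1c(Cc2c(F)cccc2F)nc(N2CCCCC2C)[nH]c1=O` differs from compound 1 by methyl in place of hydrogen on an aromatic carbon, a small change at a place that none of the measured steps touches. The data give no sign of toxicity appearing anywhere in this set, and nothing argues that this added methyl would change that. Compound 4 is therefore expected to sit at the limit as well, with an expected step that the limit leaves unreadable from compound 1 to compound 4 that would be equally unreadable. The estimate for compound 4 is 100000 nM, expected to lie between 50000 nM and 300000 nM.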

Compound 4, half-maximal cytotoxic concentration: 75000 nM
For compound 4 the middle estimate is 1.3-fold (0.12 log units) above the measured one, and the stated range covers the measured number.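

In this assay, going by these compounds alone, compound 4 gives 75000 nM, a measured number rather than a limit, which makes it the only compound of the four with one and shows that this position, para to the 2-methylpiperidin-1-yl group, can be changed with a readable result. The added methyl gives an at least 1.0-fold lower number from compound 1 to compound 4 (0.01 log units; that floor lies within the scatter), so the data show a floor for the step, and that floor alone does not establish any rise in toxicity. The true size of the step stays unknown because compound 1 sits at the limit shared by the other compounds: the limit of > 78000 nM in this assay, at which 3 of the 4 values shown sit.

Going by these compounds, whether a longer chain such as ethyl, or an amine, on this carbon would give a clearly lower number remains open. Also open, on these data alone, is whether the same methyl would behave alike with the 4-methylpiperidin-1-yl group of compound 2 or the azepan-1-yl group of compound 3.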